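The compounds below may be only part of what the source reports. "The series", "measured", "known", "first", "only" and "open" are said of these compounds alone.

Working notes on the series. Compound 1 `COc1cccc(CNCCCNc2ccnc3cc(Oc4ccc(Cl)cc4)ccc23)c1O`, compound 2 `COc1ccc(F)cc1CNCCCNc1ccnc2cc(Cc3ccccc3)ccc12` and compound 3 `COc1ccc(-c2ccc3c(NCCCNCc4cc(F)ccc4OC)ccnc3c2)cc1` have been run in an ADME assay for permeability, using PAMPA, with a stated time of 30 min, at pH 7.4; a higher number here means that the compound crosses the layer faster, a lower number that the compound crosses the layer more slowly. Compound 1 gives 317 10^-6 cm/s, compound 2 gives 23 10^-6 cm/s and compound 3 gives 237 10^-6 cm/s. Going by the values given here, compound 3 therefore sits alongside compound 1, within the scatter, while compound 2 lies well below it; the one measured step is a 10-fold higher number from compound 2 to compound 3 (1.01 log units; beyond the scatter). Compound 4 `COc1ccc(F)cc1CNCCCNc1ccnc2cc(Oc3ccc(Cl)cc3)ccc12` is next, differing from compound 3 by 4-chlorophenoxy in place of 4-methoxyphenyl on an aromatic carbon. Among the compounds with values here, no measured step covers this exchange. Because compound 1 with the same 4-chlorophenoxy group gives 317 10^-6 cm/s, compound 4 is expected to show a step of a 1.2-fold higher number from compound 3 to compound 4 (0.07 log units; within the scatter), none beyond the scatter. Compound 4 is estimated at 280 10^-6 cm/s, with a range of 140 10^-6 cm/s to 560 10^-6 cm/s in this assay.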

Compound 4, apparent permeability: 317 10^-6 cm/s
For compound 4 the middle estimate is 1.1-fold (0.05 log units) below the measured one, and the stated range covers the measured number.
By their numbers in this assay, from the lowest: compound 2; then compounds 3, 1 and 4 (each within the scatter of the next).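

In this assay the exchange of 4-methoxyphenyl for 4-chlorophenoxy on this aromatic carbon gives a 1.3-fold higher number from compound 3 to compound 4 (0.13 log units; within the scatter), while 4-chlorophenoxy in place of benzyl gives a 14-fold higher number from compound 2 to compound 4 (1.14 log units; beyond the scatter), so among these three groups only benzyl stands apart. With 4-chlorophenoxy held fixed, 5-fluoro-2-methoxyphenyl in place of 2-hydroxy-3-methoxyphenyl gives no change at the digits printed from compound 1 to compound 4 (within the scatter). Nothing available accounts for these steps. Still open, as far as these compounds go, is how an amine or a carboxylic acid on this aromatic carbon would read. From the compounds shown here alone, a longer chain between the shared core and the benzylic amine is equally open.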